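Swapping Dimethylamino for Azetidin-1-yl in Compound 1

The source may hold more compounds than are shown below. What is called first, only, known or untested is meant among the compounds shown, and "the series" means these compounds.

Among the measured compounds shown here, only two compounds have been measured. In a functional assay on cells (Lymphocyte, Homo sapiens) for inhibition, read by flow cytometry, using a membrane potential dye, with a stated time of 16 h, tested at 500 nM (on this read-out higher numbers stand for a stronger effect at the one concentration tested and lower numbers for a weaker effect), compound 1 `CCCCCCCCCCCCCCCCc1c(C)c(N(C)C)nc(C)c1O` gives 91%, and compound 2 `CCCCCCCCCCc1c(C)c(N(C)C)nc(C)c1O` gives 89%. For the measured compounds named here, the one measured step, a number 2 percentage points lower from compound 1 to compound 2 (within the scatter), concerns the long chain and not the amine. Compound 3 `CCCCCCCCCCCCCCCCc1c(C)c(N2CCC2)nc(C)c1O` differs from compound 1 in that (azetidin-1-yl in place of dimethylamino on an aromatic carbon). Going by the values given here, no measured step touches this change, so the only guide is that both measured compounds sit high in this assay. Compound 3 is therefore expected to move little, with a step of a number 6 percentage points lower from compound 1 to compound 3 (within the scatter) expected. The estimate for compound 3 is 85%, with a range from 65% to 97%.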

Compound 3, a percentage reported as activity, at one concentration (the size of the read-out at that concentration, not a potency): 89%
Compound 3: middle estimate off by 4 percentage points, on the low side; low and high end bracket the measured number.
By their numbers in this assay, from the lowest: compounds 2, 3 and 1 (each within the scatter of the next).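

In this assay, azetidin-1-yl in place of dimethylamino gives a number 2 percentage points lower from compound 1 to compound 3 (within the scatter), so at this position, para to a hydroxy group, the read-out does not tell the open amine from the four-membered ring. This read-out gives the size of the effect at one concentration, so how the two compounds compare at any other concentration stays hidden. Nothing measured explains the result.

Going by these compounds, whether piperidin-1-yl, morpholin-4-yl or a plain amino group would also keep the read-out this high remains open. So does the effect of replacing the hydroxy group with a methoxy group.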